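Chloro substitution on the pyrazoline aryl group of compound 1

The compounds below may be only part of what the source reports. "The series", "measured", "known", "first", "only" and "open" are said of these compounds alone.

Compound 1 `c1ccc(C2=NN(c3ccc(-c4ccccc4)nn3)C(c3ccccc3)C2)cc1` is the unsubstituted parent of the series. In a functional assay on A549 cells (Homo sapiens) for antiproliferative activity, read by MTT assay, with a stated time of 24 h (on this read-out lower numbers stand for stronger inhibition and higher numbers for weaker inhibition), compound 1 gives only a limit, > 100000 nM, and no number. That limit is the limit of > 100000 nM in this assay, at which 1 of the 3 values shown sits, so compound 1 stands at the weak end of what the assay resolves. Compound 2 `COc1ccc(C2CC(c3ccccc3)=NN2c2ccc(-c3ccccc3)nn2)cc1` gives 91700 nM in this assay, and compound 3 `COc1ccc(C2CC(c3ccccc3)=NN2c2ccc(-c3ccccc3)nn2)c(OC)c1` gives 9560 nM. The step of an at least 1.0-fold lower number from compound 1 to compound 2 (0.03 log units; that floor lies within the scatter) stays within the scatter, whereas a 9.6-fold lower number from compound 2 to compound 3 (0.98 log units; beyond the scatter) and an at least 10-fold lower number from compound 1 to compound 3 (1.01 log units; beyond the scatter) lie beyond it; both of those concern the phenyl on the saturated ring carbon.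

Compound 4 `Clc1ccc(C2=NN(c3ccc(-c4ccccc4)nn3)C(c3ccccc3)C2)cc1` differs from compound 1 by chloro in place of hydrogen on an aromatic carbon. Among the measured compounds shown here, no measured step touches this ring, and the only step that changes a single aromatic hydrogen on the other ring, an at least 1.0-fold lower number from compound 1 to compound 2 (0.03 log units; that floor lies within the scatter), produced no movement beyond the scatter. The expectation for compound 4 is therefore a step of an at least 1.2-fold lower number from compound 1 to compound 4 (0.09 log units; that floor lies within the scatter), with little change in this assay. Compound 4 is estimated at 80000 nM, within 20000 nM to 300000 nM.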

Compound 4, half-maximal inhibitory concentration: 96700 nM
The estimate for compound 4 lay 1.2-fold (0.08 log units) below the measured number; the range from low to high includes it.
By their numbers in this assay, from the lowest: compound 3; then compounds 2 and 4 (each within the scatter of the next). At a limit, above all of these: compound 1.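

In this assay, among the compounds shown here, the change from phenyl to 4-chlorophenyl gives an at least 1.0-fold lower number from compound 1 to compound 4 (0.01 log units; that floor lies within the scatter), so the first reading on this ring shows no movement beyond the scatter. The value of compound 1 is a limit and not a number, so this step gives only a floor: the limit of > 100000 nM in this assay, at which 1 of the 4 values shown sits. Compound 4 gives an actual number, 96700 nM, so later changes on this ring can be read against compound 4 as a reference.

Going by these compounds, whether an amine or a carboxylic acid in place of the chloro would move the number beyond the scatter remains open. Also open, on these data alone, is whether the 4-chlorophenyl change would behave the same way in compound 3, which carries the 2,4-dimethoxyphenyl group on the saturated ring carbon.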